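Pyridin-3-yl for thiophen-2-yl in a level series

The source may hold more compounds than are shown below. What is called first, only, known or untested is meant among the compounds shown, and "the series" means these compounds.

In a functional assay on SGC-7901 cells (Homo sapiens) for cytotoxicity, read by MTT assay, with a stated time of 48 h (on this read-out higher numbers stand for weaker inhibition and lower numbers for stronger inhibition), compound 1 `Cc1ccccc1-c1nnc(SCCn2c([N+](=O)[O-])cnc2C)o1` gives 32300 nM while compound 2 `Cc1ccc(-c2nnc(SCCn3c([N+](=O)[O-])cnc3C)o2)c(O)c1` gives 36700 nM and compound 3 `Cc1ncc([N+](=O)[O-])n1CCSc1nnc(-c2cccs2)o1` gives 30800 nM with all of them sharing one core. Compound 3 therefore stands level with the other two, and its value cannot be separated from theirs. The next compound is compound 4 `Cc1ncc([N+](=O)[O-])n1CCSc1nnc(-c2cccnc2)o1` which carries pyridin-3-yl in place of thiophen-2-yl on an aromatic carbon of a five-membered aromatic ring with 2 nitrogen and 1 oxygen pyridin-3-yl in place of thiophen-2-yl on an aromatic carbon and is otherwise the same as compound 3.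

Three measured steps change the group at this same place. Replacing 2-methylphenyl with thiophen-2-yl gave a 1.0-fold lower number from compound 1 to compound 3 (0.02 log units; within the scatter) and replacing 2-hydroxy-4-methylphenyl with thiophen-2-yl gave a 1.2-fold lower number from compound 2 to compound 3 (0.08 log units; within the scatter) while the exchange of the two phenyl groups gave a 1.1-fold higher number from compound 1 to compound 2 (0.06 log units; within the scatter) so none of the three separates the compounds. Among the measured compounds shown here, no measured compound carries pyridin-3-yl, so this group itself remains untested. On these steps alone, no change beyond the scatter is expected in this assay for the new exchange. The expected step is a 1.0-fold higher number from compound 3 to compound 4 (0.02 log units; within the scatter) on this estimate. Compound 4 is estimated at 32000 nM with an expected range from 15000 nM to 68000 nM once it is measured.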

Compound 4, half-maximal inhibitory concentration: 31600 nM
The estimate for compound 4 lay 1.0-fold (0.01 log units) above the measured number, within the range that was stated.
By their numbers in this assay, from the lowest: compounds 3, 4, 1 and 2 (each within the scatter of the next).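

In this assay, the six-membered pyridin-3-yl ring cannot be told apart at this position from the five-membered thiophen-2-yl ring (a 1.0-fold higher number from compound 3 to compound 4 (0.01 log units; within the scatter)), and it is equally level with the two substituted phenyl groups (a 1.2-fold lower number from compound 2 to compound 4 (0.06 log units; within the scatter); a 1.0-fold lower number from compound 1 to compound 4 (0.01 log units; within the scatter)). The level series now also takes in a group with a ring nitrogen, so on this aromatic carbon neither the change of ring size nor the exchange of sulfur for nitrogen in the ring separates compound 4 from compound 1, compound 2 or compound 3. Nothing measured here bears on why the numbers stay level at this position.

All four compounds keep an aromatic ring on this carbon, which leaves open whether a group of another kind, such as an amine, a carboxylic acid or a longer alkyl chain, would move the number beyond the scatter. The rest of the shared core is the same in all of them, so they cannot show whether a change elsewhere in the molecule would shift the values or make this position matter.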